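Moving from methoxy to fluoro at an assay limit

A few compounds are considered here, and "the series" means these few. Any claim that something is new, unique, unknown or untested is made for them only; others in the source may bear on it.

- Compound 1 `O=c1c(-c2ccc(F)cc2)cn(C2CC2)c2cc(N3CCNCC3)c(F)cc12` gives > 400000 nM (a limit)
- Compound 2 `COc1ccc(-c2cn(C3CC3)c3cc(N4CCNCC4)c(F)cc3c2=O)cc1` gives > 400000 nM (a limit)

In a physicochemical assay for solubility, at pH 7.9 (a higher number here means a more soluble compound, a lower number a less soluble compound), compound 1 reads > 400000 nM, which is a limit of the assay and not a number. Compound 2 reads > 400000 nM, again only a limit. Compound 2 therefore stands at the limit of > 400000 nM in this assay, at which 2 of the 2 values shown sit, and no exact figure exists for it.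

The next compound is compound 3 `O=c1c(-c2cccc(F)c2)cn(C2CC2)c2cc(N3CCNCC3)c(F)cc12`, which has 3-fluorophenyl in place of 4-methoxyphenyl on an aromatic carbon. Counted, the change is 3-fluorophenyl in place of 4-methoxyphenyl on an aromatic carbon.

For the measured compounds named here, the only measured step that bears on this is a step that the two limits leave unreadable from compound 1 to compound 2, where methoxy takes the place of fluoro on an aromatic carbon. That step offers no size to carry over, so no change beyond the scatter is expected in this assay, and another reading at the limit seems likely. The expected step is a number no higher from compound 2 to compound 3 (the limit leaves the size open). The estimate for compound 3 is 400000 nM, with an expected range from 200000 nM to 800000 nM.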

Compound 3, solubility: > 400000 nM
Compound 3: only a limit was reported; the forecaster's own chance of this, stated with the estimate: 75%; the middle value sits exactly at the limit.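

In this assay compound 3 gives > 400000 nM, again a limit of the assay and not a number. No step among compound 1, compound 2 and compound 3 can therefore be read, because all three stand at the same point: the limit of > 400000 nM in this assay, at which 3 of the 3 values shown sit. The compounds shown leave open how far apart these three truly lie in this assay.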